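A few compounds are considered here, and "the series" means these few. Any claim that something is new, unique, unknown or untested is made for them only; others in the source may bear on it.

Within this small series the ring nitrogen of the shared core carries three different groups. Compound 1 `COC(=O)N1CCC(Oc2ncnc3c2CCN3c2ccc(S(C)(=O)=O)cc2F)CC1` gives, in a functional assay on CHO-K1 cells for agonist activity at Glucose-dependent insulinotropic receptor (Homo sapiens), read by a luciferase reporter, with a stated time of 5 h (a higher number here means that more compound is needed for the effect, a lower number that less compound is needed), a value of 316 nM; compound 2 `COCCOC(=O)N1CCC(Oc2ncnc3c2CCN3c2ccc(S(C)(=O)=O)cc2F)CC1` gives 316 nM in this assay; and compound 3 `CCS(=O)(=O)N1CCC(Oc2ncnc3c2CCN3c2ccc(S(C)(=O)=O)cc2F)CC1` gives 1580 nM, which stands highest of the three numbers, the nearest being compound 1 and the furthest compound 2, both at the same distance. Compound 1 and compound 2 differ by no change at the digits printed from compound 1 to compound 2 (within the scatter), while the two steps to compound 3 were a 5.0-fold higher number from compound 1 to compound 3 (0.70 log units; beyond the scatter) and a 5.0-fold higher number from compound 2 to compound 3 (0.70 log units; beyond the scatter), both beyond the scatter.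

Compound 4 `CN(C)C(=O)CN1CCC(Oc2ncnc3c2CCN3c2ccc(S(C)(=O)=O)cc2F)CC1` has not yet been measured. It differs from compound 3 in that ((dimethylcarbamoyl)methyl in place of ethylsulfonyl on an amine nitrogen in a ring). Among the measured compounds shown here, no measured step covers this exact exchange; the steps that bear on it are those from the carbamates to compound 3, which showed that replacing a carbonyl-bearing group on this ring nitrogen with an ethylsulfonyl raised the number modestly. Removing the ethylsulfonyl again might therefore be expected to bring the number back downward, but the entering group is neither of the carbamates, so the expectation is hedged: a step of a 2.0-fold lower number from compound 3 to compound 4 (0.30 log units; within the scatter) is estimated. Compound 4 is accordingly expected to give about 800 nM in this assay, with a plausible range from 200 nM to 3200 nM.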

Compound 4, half-maximal effective concentration: > 10000 nM
Compound 4: only a limit was reported; the forecaster's own chance of this, stated with the estimate: 5%; middle value at least 12-fold (1.09 log units) from the limit.
By their numbers in this assay, from the lowest: compounds 1 and 2 (each within the scatter of the next); then compound 3. At a limit, above all of these: compound 4.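

In this assay compound 4 gives only a limit of the assay, not a number: the limit of > 10000 nM in this assay, at which 1 of the 4 values shown sits. Among the compounds shown here, this position therefore does not accept every group that holds a carbonyl: the carbamates of compounds 1 and 2 and the ethylsulfonyl of compound 3 all gave measured values, whereas (dimethylcarbamoyl)methyl, the only one of the four groups with a carbonyl in an amide, gave none, with an at least 6.3-fold higher number from compound 3 to compound 4 (0.80 log units; beyond the scatter) and large steps of an at least 31-fold higher number from compound 2 to compound 4 (1.50 log units; beyond the scatter) and an at least 31-fold higher number from compound 1 to compound 4 (1.50 log units; beyond the scatter). For the compounds shown here, the earlier compounds showed only a modest spread at this amine nitrogen, so this exchange is the first to show that a change here can take the compound out of the measurable range altogether.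

On these data alone, since the result is a limit, the true size of these steps stays unknown, and the four compounds do not separate the effect of the amide from that of the chain that carries it. As far as these compounds go, how a simple ethyl chain, an acetyl group or a urea on this ring nitrogen would compare with the carbamates and with compound 4 also remains open.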